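Cyclopropyl in place of ethyl: compound 3 to compound 4

The source may hold more compounds than are shown below. What is called first, only, known or untested is meant among the compounds shown, and "the series" means these compounds.

Compound 1 `COc1ccc(Cn2c(C(=O)N3CCC(C(=O)NCc4cccc(Br)c4)CC3)cc3sccc32)cc1`: > 100000 nM, a limit of the assay and not a number
Compound 2 `CCCCC(=O)C1CCN(C(=O)c2cc3sccc3n2Cc2ccc(OC)cc2)CC1`: 38900 nM
Compound 3 `CCCNC(=O)C1CCN(C(=O)c2cc3sccc3n2Cc2ccc(OC)cc2)CC1`: 18800 nM

All three results come from an ADME assay on HEK-293T cells (Homo sapiens) for cytotoxicity, read by luminescence, with a stated time of 24 h; a higher number here means that more compound is tolerated, a lower number that less compound is tolerated. Compound 3 holds the lower of the two actual numbers, and the gap to the other is modest: a 2.1-fold lower number from compound 2 to compound 3 (0.32 log units; beyond the scatter). Compound 1 gives only a limit.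

The next compound, compound 4 `COc1ccc(Cn2c(C(=O)N3CCC(C(=O)NCC4CC4)CC3)cc3sccc32)cc1`, differs from compound 3 in one place: cyclopropyl in place of ethyl on a saturated chain carbon bound to an amide-type nitrogen. In words, this is cyclopropyl in place of ethyl on a saturated chain carbon bound to an amide-type nitrogen. Among the compounds with values here, the one measured step at that same place is an at least 5.3-fold lower number from compound 1 to compound 3 (0.72 log units; beyond the scatter). That step is open at one end, since compound 1 stands at the limit of > 100000 nM in this assay, at which 1 of the 3 values shown sits. The step of a 2.1-fold lower number from compound 2 to compound 3 (0.32 log units; beyond the scatter) is a change in the same side chain, and it is modest. Neither step tests a cyclopropyl group directly, so they give only a rough guide. A small rise in the number is expected, no larger than that modest step and possibly within the scatter. The expected step is a 1.3-fold higher number from compound 3 to compound 4 (0.11 log units; within the scatter). For compound 4 the estimate is 24000 nM, with an expected range from 11000 nM to 55000 nM.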

Compound 4, half-maximal cytotoxic concentration: 24600 nM
Compound 4: the middle estimate sits 1.0-fold (0.01 log units) below what was measured, and the stated range covers the measured number.
By their numbers in this assay, from the lowest: compounds 3, 4 and 2 (each within the scatter of the next, the first and the last beyond it). At a limit, above all of these: compound 1.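

In this assay, a three-membered non-aromatic ring of carbon only can take the place of ethyl on a saturated chain carbon bound to an amide-type nitrogen without moving the number beyond the scatter: a 1.3-fold higher number from compound 3 to compound 4 (0.12 log units; within the scatter). The same holds for the change on the carbonyl carbon, where the earlier step, a 2.1-fold lower number from compound 2 to compound 3 (0.32 log units; beyond the scatter), lay beyond the scatter but the new one, a 1.6-fold lower number from compound 2 to compound 4 (0.20 log units; within the scatter), lies within it, so replacing butyl with a substituted amino group does not always separate the two numbers. The step from the 3-bromophenyl group remains beyond the scatter, an at least 4.0-fold lower number from compound 1 to compound 4 (0.60 log units; beyond the scatter), and it is open at one end, since compound 1 stands at a limit and not a number: the limit of > 100000 nM in this assay, at which 1 of the 4 values shown sits.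

The compounds shown do not separate the part played by the bromine from that of the ring, which a plain phenyl group at this place would do. They also leave open what a cyclohexyl group, a longer chain, an amine or a carboxylic acid would give here.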